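The source may report more compounds than this note shows. Statements on the series, on what has been measured and on what is new or still open speak of the compounds shown alone.

Compound 1 `COc1cc(/C=C2\CN(C)C/C(=C\c3cccnc3)C2=O)cc(OC)c1OC` gives 4300 nM
Compound 2 `CN1C/C(=C\c2ccncc2)C(=O)/C(=C/c2cc([N+](=O)[O-])ccc2F)C1` gives 5700 nM
Compound 3 `O=C1/C(=C/c2cccnc2)CN(S(=O)(=O)c2ccccc2)C/C1=C\c1ccccc1F` gives 4800 nM

These three values all come from a functional assay on QGY-7703 cells (Homo sapiens) for cytotoxicity, read by MTT assay, with a stated time of 24 h; on this read-out lower numbers stand for stronger inhibition and higher numbers for weaker inhibition. Compound 3 (4800 nM) lies within the usual scatter of both compound 1 and compound 2, so the numbers set no order among the three.

The next molecule, compound 4 `O=C1/C(=C/c2cccnc2)CN(S(=O)(=O)c2ccc(F)cc2)C/C1=C\c1ccccc1F`, keeps compound 3 intact apart from one change: its phenylsulfonyl group becomes (4-fluorophenyl)sulfonyl. The difference fluoro in place of hydrogen on an aromatic carbon is fluoro in place of hydrogen on an aromatic carbon, para to a large group.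

Among the compounds with values here, no two measured compounds differ in only one place, so the data give no direct measure of what this swap does. They do show that compound 1 (4300 nM) and compound 2 (5700 nM) sit close to compound 3 (4800 nM) even though both differ from it in more than one place. On that basis, a single fluoro swap is expected to give no step beyond the scatter in this assay, in either direction. The expected change is a 1.1-fold lower number from compound 3 to compound 4 (0.03 log units; within the scatter) and would not stand out from repeat measurements. Compound 4 is expected at 4500 nM (estimated range 2400 nM to 8500 nM).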

Compound 4, half-maximal inhibitory concentration: 15300 nM
The estimate for compound 4 lay 3.4-fold (0.53 log units) below the measured number; measured number above the stated range.
By their numbers in this assay, from the lowest: compounds 1, 3 and 2 (each within the scatter of the next); then compound 4.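

In this assay, within the data shown here, the swap of fluoro in place of hydrogen on the phenylsulfonyl group gives a 3.2-fold higher number from compound 3 to compound 4 (0.50 log units; beyond the scatter), and it is the only step here that can be read from compounds differing in one place. It shows that this position, para to a large group, is not indifferent to change: a single added heavy atom, with no ring, no charge and no hydrogen-bond donor or acceptor counted for it, is enough to carry the number past the usual scatter, towards weaker inhibition. Nothing measured here explains why this small change has that effect.

One step at one position cannot show whether the weaker inhibition is particular to fluoro or would follow from any group placed there, and a chloro, a methyl or an amine at the same place would help to separate those two readings. Going by these compounds, it also remains open whether the same swap would give a similar step when the rest of the molecule differs, since the shared core carries different groups across these compounds.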